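Series notes: from fluoro to chloro

This account rests on a few compounds, and the source may have more. Where it says the series, first, only, none or still open, it means among the compounds named here.

Of the compounds shown here, two have been measured so far. In a physicochemical assay for solubility, read by HPLC, in phosphate buffer, measured as kinetic solubility, at pH 7.4 (on this read-out higher numbers stand for higher solubility and lower numbers for lower solubility), compound 1 `CCC(=O)c1cc(-c2ccc(Cl)cc2)n(-c2ccc(S(N)(=O)=O)cc2)n1` gives 37800 nM and compound 2 `CCOC(=O)c1cc(-c2ccc(F)cc2)n(-c2ccc(S(N)(=O)=O)cc2)n1` gives 56400 nM. These two values lie within the scatter of each other, so compound 2 stands level with compound 1 on the numbers available. Going by the values given here, no pair of measured compounds differs in only one place, which leaves the size of the present change unshown by the data.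

Compound 3 `CCOC(=O)c1cc(-c2ccc(Cl)cc2)n(-c2ccc(S(N)(=O)=O)cc2)n1` has not yet been measured. It differs from compound 2 by chloro in place of fluoro on an aromatic carbon, para to a large group: chloro in place of fluoro on an aromatic carbon. Cut one bond further out, the same difference reads 4-fluorophenyl to 4-chlorophenyl.

Among the compounds with values here, compound 1 also carries 4-chlorophenyl and gives 37800 nM, the only measured guide for this group, so the expectation leans slightly toward a lower number in this assay. The expected step, a 1.6-fold lower number from compound 2 to compound 3 (0.19 log units; within the scatter), is estimated to stay within the scatter. For compound 3 the expected value is 36000 nM, with an estimated range of 15000 nM to 70000 nM.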

Compound 3, solubility: 53300 nM
Beside the measured number, compound 3's estimate is 1.5-fold (0.17 log units) below it; the measured number falls inside the stated range.
By their numbers in this assay, from the lowest: compounds 1, 3 and 2 (each within the scatter of the next).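

Going by these compounds alone, at this place, on an aromatic carbon para to a large group, the first comparison that differs only in the halogen gives in this assay a 1.1-fold lower number from compound 2 to compound 3 (0.02 log units; within the scatter), so with the ethoxy on the carbonyl carbon held constant, 4-chlorophenyl and 4-fluorophenyl cannot be told apart on this read-out. The series also gains its first single-place comparison at the carbonyl carbon, where ethoxy in place of ethyl with 4-chlorophenyl held constant gives a 1.4-fold higher number from compound 1 to compound 3 (0.15 log units; within the scatter), so neither change has yet produced a step beyond the scatter. No accompanying measurement speaks to what lies behind either step.

On these data alone, each step rests on a single pair, and it remains open whether the same holds for a methoxy, an amine or a nitrile on that aromatic carbon, in place of the halogens. As far as these compounds go, on the carbonyl carbon, it also remains open how a hydroxyl, giving a carboxylic acid, or an amine, giving an amide, would compare with ethoxy and ethyl, and whether the halogen step stays the same with ethyl in place of ethoxy.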